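The source may report more compounds than this note shows. Statements on the series, on what has been measured and on what is new or still open speak of the compounds shown alone.

Two compounds anchor this comparison. Compound 1 `COC(=O)/C=C/c1cccc(N(Cc2ccc(-c3cccc(OC)c3)cc2)C(=O)NC(C)C)c1` is the weaker of the pair: in an assay on isolated protein with Bile acid receptor (Homo sapiens) as the target (on this read-out lower numbers stand for an effect already at smaller amounts and higher numbers for an effect only at larger amounts of compound), compound 1 gives 1370 nM. Compound 2 `COC(=O)/C=C/c1cccc(N(Cc2ccc(-c3ccc(F)c(Cl)c3)cc2)C(=O)C2CCCCC2)c1` carries a cyclohexyl amide and a 3-chloro-4-fluorophenyl on the biaryl, and in this assay compound 2 gives 66 nM, the lower of the two numbers, with compound 1 standing beyond the usual scatter above it.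

Compound 3 `COC(=O)/C=C/c1cccc(N(Cc2ccc(Br)cc2)C(=O)C2CCCCC2)c1` keeps the cinnamate and cyclohexyl amide of compound 2 but removes the distal ring entirely (bromo in place of 3-chloro-4-fluorophenyl on an aromatic carbon). Among the compounds with values here, no measured pair within this set shows such a change, so its size cannot be read from a neighbouring step. Because compound 2 reaches 66 nM with its full biaryl in place, the expectation is that trimming it to a single bromo will cost activity in this assay, giving a higher number by a step of a 9.1-fold higher number from compound 2 to compound 3 (0.96 log units; beyond the scatter) that is expected to lie beyond the scatter. Compound 3 is therefore estimated at 600 nM, within a range of 150 nM to 2500 nM.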

Compound 3, half-maximal effective concentration: > 1000 nM
Compound 3 was reported as a limit (the forecaster's own chance of this, stated with the estimate: 10%); middle value at least 1.6-fold (0.22 log units) away from the limit.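

Putting bromo in place of 3-chloro-4-fluorophenyl, on an aromatic carbon para to a large group, gives an at least 15-fold higher number from compound 2 to compound 3 (1.18 log units; beyond the scatter) in this assay, with the rest of the structure unchanged. Within the data shown here, this is the first reading that ties a change in activity to this position alone: compound 1 and compound 2 differ in more than one place, so the gap between them could not be assigned to the distal ring, whereas this single change shows that the 3-chloro-4-fluorophenyl cannot be traded for bromo without a large rise in the number. Compound 3 is reported as a limit and not as a number, so the step gives only the smallest size the change can have: the limit of > 1000 nM in this assay, at which 1 of the 3 values shown sits.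

The compounds shown do not separate the loss of the ring itself from the loss of its chlorine and fluorine, and a plain phenyl or a 4-fluorophenyl at this position would divide the two. Going by these compounds, it also remains open whether the same change would weigh as heavily with the isopropyl urea of compound 1 in place of the cyclohexyl amide, or with a carboxylic acid in place of the methyl ester.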